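Methyl in Place of Hydrogen: From Compound 2 to Compound 3

The source may report more compounds than this note shows. Statements on the series, on what has been measured and on what is new or still open speak of the compounds shown alone.

In a functional assay on HT-29 cells (Homo sapiens) for cytotoxicity, read by MTT assay, with a stated time of 72 h (on this read-out higher numbers stand for weaker inhibition and lower numbers for stronger inhibition), compound 1 `O=C(Nc1nc2ccccc2s1)c1cn(-c2ccccc2)nc1-c1ccccc1` gives 16800 nM and compound 2 `O=C(Nc1nc2ccccc2s1)c1cn(-c2ccccc2)nc1-c1ccc(Cl)cc1` gives 13700 nM; compound 2 thus stands alongside compound 1 in this assay, the step of a 1.2-fold lower number from compound 1 to compound 2 (0.09 log units; within the scatter) being within the scatter. Compound 3 `Cc1ccc2nc(NC(=O)c3cn(-c4ccccc4)nc3-c3ccc(Cl)cc3)sc2c1` differs from compound 2 by methyl in place of hydrogen on an aromatic carbon, which cut one bond further out reads 1,3-benzothiazol-2-yl to 6-methyl-1,3-benzothiazol-2-yl. Among the compounds with values here, no measured step touches this ring; the only step known is a 1.2-fold lower number from compound 1 to compound 2 (0.09 log units; within the scatter), on a different ring. The author therefore expects no step beyond the scatter, a 1.1-fold lower number from compound 2 to compound 3 (0.06 log units; within the scatter). Compound 3 is estimated at 12000 nM, between 5000 nM and 30000 nM.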

Compound 3, half-maximal inhibitory concentration: 23700 nM
Estimate against measurement, compound 3: 2.0-fold (0.30 log units) below; low and high end bracket the measured number.
By their numbers in this assay, from the lowest: compounds 2, 1 and 3 (each within the scatter of the next).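

In this assay, within the data shown here, the change to 6-methyl-1,3-benzothiazol-2-yl gives the first reading at this position, a 1.7-fold higher number from compound 2 to compound 3 (0.24 log units; within the scatter), so a methyl here is not told apart from hydrogen. The earlier step lay on a different ring, and this ring too now shows no step beyond the scatter. No evidence bearing on this result is available.

The compounds shown leave open whether an amine, a carboxylic acid or a longer chain at this position would move the number beyond the scatter. They also leave open whether such a group would do so on the other rings.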